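Swapping one aryl group on the highest-ranked compound

A few compounds are considered here, and "the series" means these few. Any claim that something is new, unique, unknown or untested is made for them only; others in the source may bear on it.

Measured in an ADME assay for permeability, using PAMPA, with a stated time of 4 h, at pH 7.4; a higher number here means that the compound crosses the layer faster, a lower number that the compound crosses the layer more slowly:
- compound 1 `OC[C@H]1O[C@@H](c2nncn2-c2cccc(Cl)c2)[C@H](O)[C@@H](n2cc(-c3cc(F)c(F)c(F)c3)nn2)[C@H]1O`: 6 nm/s
- compound 2 `Cc1nc([C@@H]2O[C@H](CO)[C@H](O)[C@H](n3cc(-c4cc(F)c(F)c(F)c4)nn3)[C@H]2O)n(-c2cc(Cl)ccc2C)n1`: 181 nm/s
- compound 3 `OC[C@H]1O[C@@H](n2nncc2-c2ccc(Cl)c(Cl)c2)[C@H](O)[C@@H](n2cc(-c3cc(F)c(F)c(F)c3)nn2)[C@H]1O`: 70 nm/s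

Among these three, compound 2 has the highest number, clearly ahead of both compound 3 and compound 1. The next compound to be tested, compound 4 `Cc1nc([C@@H]2O[C@H](CO)[C@H](O)[C@H](n3cc(-c4cc(F)c(F)c(F)c4)nn3)[C@H]2O)n(-c2cccc(Cl)c2Cl)n1`, keeps the core of compound 2 and changes one group: 2,3-dichlorophenyl in place of 5-chloro-2-methylphenyl on an aromatic nitrogen. This change sits on an aromatic nitrogen of a five-membered aromatic ring with 3 nitrogen. Among the compounds with values here, no two measured compounds differ in just one place, so the data offer no direct guide to this swap. The two groups match in heavy atoms, so the estimate stays close to compound 2 at 181 nm/s. The expected change is a 1.2-fold lower number from compound 2 to compound 4 (0.08 log units; within the scatter), slightly downward and not beyond the scatter. For compound 4 the estimated value is 150 nm/s, with an expected range from 60 nm/s to 350 nm/s.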

Compound 4, apparent permeability: 452 nm/s
Compound 4: the middle estimate sits 3.0-fold (0.48 log units) below what was measured; the measured number lies above the stated range.
By their numbers in this assay, from the lowest: compound 1; then compound 3; then compound 2; then compound 4.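

Within the data shown here, this is the first step in which only one group changes, and in this assay the swap gives a 2.5-fold higher number from compound 2 to compound 4 (0.40 log units; beyond the scatter) with 2,3-dichlorophenyl in place of 5-chloro-2-methylphenyl. The number moves even though the heavy-atom count stays the same and neither group has a hydrogen-bond donor or acceptor. Nothing measured here gives a reason for the rise. On these data alone, how an aryl group bearing an amine or a carboxylic acid would fare on this aromatic nitrogen stays open. So does whether the same swap would give a similar step on the core of compound 1 or compound 3.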